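Removing the Methyl from the Ring Nitrogen of Compound 1

The compounds below may be only part of what the source reports. "The series", "measured", "known", "first", "only" and "open" are said of these compounds alone.

Measured compounds:
compound 1, `COc1ccccc1/C=c1/[nH]c(=O)/c(=C\c2ccccc2OC)n(C)c1=O`: 16900 nM
compound 2, `C=CCn1c(=O)/c(=C\c2cccc(Br)c2)[nH]c(=O)/c1=C\c1ccccc1OC`: "not active" (no number reported)
compound 3, `COc1ccccc1/C=c1\c(=O)[nH]/c(=C/c2cccc(Cl)c2Cl)c(=O)n1C`: 300 nM

In a functional assay on NCI-H1975 cells (Homo sapiens) for cytotoxicity, read by CCK-8 assay, with a stated time of 72 h (on this read-out higher numbers stand for weaker inhibition and lower numbers for stronger inhibition), compound 1 gives 16900 nM, the higher of the two numbers reported. Compound 3 gives 300 nM. Compound 2 is recorded as "not active" (no number reported), with no number. For the measured compounds named here, the only step between compounds that differ in one place is a 56-fold lower number from compound 1 to compound 3 (1.75 log units; beyond the scatter), which replaces the methoxyphenyl on the double-bonded chain carbon with a dichlorophenyl.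

Compound 4, `COc1ccccc1/C=c1/[nH]c(=O)/c(=C\c2ccccc2OC)[nH]c1=O`, keeps the core of compound 1 and differs only by hydrogen in place of methyl on an aromatic nitrogen. Going by the values given here, no measured pair changes this ring nitrogen, so the step from compound 1 to compound 3 has no direct bearing on it and the series offers no guide to size or direction. The expectation is therefore a step within scatter, a 1.0-fold higher number from compound 1 to compound 4 (0.00 log units; within the scatter), with wide uncertainty. Compound 4 is estimated at 17000 nM in this assay, with a range of 4000 nM to 70000 nM.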

Compound 4, half-maximal inhibitory concentration: "not active" (no number reported)
Compound 4: no number reported, and the estimate cannot be compared.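

In this assay, for the compounds shown here, compound 4 gives "not active" (no number reported), so no step from compound 1 to compound 4 can be read. The compounds shown leave open how far hydrogen in place of methyl on the aromatic nitrogen shifts the read-out. No available evidence accounts for this result.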